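Swapping the Ring at the End of the Chain

The compounds below may be only part of what the source reports. "The series", "measured", "known", "first", "only" and "open" are said of these compounds alone.

Compound 3 `C#CCOc1cccc(/C=C/C(=O)Nc2cc(C(=O)c3cc(OC)c(OC)c(OC)c3)ccc2OC)c1` has the highest number of the three compounds measured in a functional assay on ME-180 cells (Homo sapiens) for cytotoxicity, read by MTT assay, with a stated time of 72 h; a lower number here means a stronger inhibitor, a higher number a weaker inhibitor: compound 3 gives 15300 nM. Compound 2 `COc1ccc(/C=C/C(=O)Nc2cc(C(=O)c3cc(OC)c(OC)c(OC)c3)ccc2OC)cc1` gives 11800 nM, and compound 1 `COc1ccc(C(=O)c2cc(OC)c(OC)c(OC)c2)cc1N` gives 80 nM. The step of a 1.3-fold higher number from compound 2 to compound 3 (0.11 log units; within the scatter) shows that exchanging one ring group for another at the end of the chain changed little. Compound 4 `COc1ccc(C(=O)c2cc(OC)c(OC)c(OC)c2)cc1NC(=O)/C=C/c1ccc(F)cc1` differs from compound 3 by the change (4-fluorophenyl in place of 3-(propargyloxy)phenyl on a double-bonded chain carbon bound to a double-bonded chain carbon), the same kind of exchange at the same place. Because a 1.3-fold higher number from compound 2 to compound 3 (0.11 log units; within the scatter) stayed within the scatter, no step beyond the scatter is expected for compound 4, an estimated 1.3-fold lower number from compound 3 to compound 4 (0.11 log units; within the scatter). Compound 4 is therefore estimated at 12000 nM, within 4000 nM to 40000 nM.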

Compound 4, half-maximal inhibitory concentration: 300 nM
For compound 4 the middle estimate is 40-fold (1.60 log units) above the measured one, and the stated range ends above it.
By their numbers in this assay, from the lowest: compound 1; then compound 4; then compounds 2 and 3 (each within the scatter of the next).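

The ring at the end of the chain matters a great deal in this assay, since 4-fluorophenyl in place of 3-(propargyloxy)phenyl gives a large step (a 51-fold lower number from compound 3 to compound 4 (1.71 log units; beyond the scatter)), and fluoro in place of methoxy on the aromatic carbon gives another (a 39-fold lower number from compound 2 to compound 4 (1.59 log units; beyond the scatter)). The earlier exchange at this place stayed within the scatter, so this position does not tolerate every ring group equally. Putting (2-(4-fluorophenyl)ethenyl)carbonyl in place of hydrogen on the nitrogen still costs a modest step (a 3.8-fold higher number from compound 1 to compound 4 (0.57 log units; beyond the scatter)).

No evidence here explains these differences. Going by these compounds, whether chloro or an amine on this ring would perform like fluoro remains open.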